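The source may hold more compounds than are shown below. What is called first, only, known or untested is meant among the compounds shown, and "the series" means these compounds.

Compound 1 `COC(=O)/C(=C/Cn1c(-c2ccccc2)ncc(NC(=O)OCc2ccccc2)c1=O)COC(=O)c1ccc([N+](=O)[O-])cc1` gives 3.6 ug/mL in a functional assay on cells (Macrophage cell line, Homo sapiens) for inhibition (a lower number here means a stronger inhibitor, a higher number a weaker inhibitor), the lowest of the two numbers recorded so far. Compound 2 `COC(=O)/C(=C/[C@H](C)NC(=O)Cn1c(-c2ccccc2)ncc(NC(=O)OCc2ccccc2)c1=O)COC(C)=O` sits nearest, with 5.4 ug/mL in this assay, a gap that lies within the scatter. Compound 3 `COC(=O)/C(=C/Cn1c(-c2ccccc2)ncc(NC(=O)OCc2ccccc2)c1=O)COC(C)=O` has not yet been measured; it differs from compound 1 by methyl in place of 4-nitrophenyl on a carbonyl carbon, so the ((4-nitrophenyl)carbonyl)oxy group becomes acetoxy. Within the data shown here, no measured pair shows this change. A modest shift towards weaker inhibition, or none beyond the scatter, is expected, and the estimate for compound 3 is 5.5 ug/mL, between 2 ug/mL and 14 ug/mL, which means an expected step of a 1.5-fold higher number from compound 1 to compound 3 (0.18 log units; within the scatter).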

Compound 3, half-maximal inhibitory concentration: 1.08 ug/mL
For compound 3 the middle estimate is 5.1-fold (0.71 log units) above the measured one, and the stated range ends above it.
By their numbers in this assay, from the lowest: compound 3; then compounds 1 and 2 (each within the scatter of the next).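

In this assay, methyl in place of 4-nitrophenyl on a carbonyl carbon gives a 3.3-fold lower number from compound 1 to compound 3 (0.52 log units; beyond the scatter). This shows that the ((4-nitrophenyl)carbonyl)oxy group is not needed for inhibition here and that acetoxy is better tolerated at this place, a step that compound 1 and compound 2, differing in more than one place, could not show. Nothing measured here accounts for the gain.

The compounds shown leave open whether the nitro group or the whole ring accounts for the step, which an unsubstituted benzoyl ester would separate. They also leave open how a free hydroxyl or a longer acyl chain would behave at this place.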